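Working notes: a methyl step from compound 2

The source may report more compounds than this note shows. Statements on the series, on what has been measured and on what is new or still open speak of the compounds shown alone.

Compound 1 `COc1ccc2[nH]c(-c3ccc[nH]3)c(C3CC(=O)NC3=O)c2c1` gives 6000 nM
Compound 2 `O=C1CC(c2c(-c3ccc[nH]3)[nH]c3ccccc23)C(=O)N1` gives 25000 nM
Compound 3 `Cc1ccc2[nH]c3c(c4c(c5ccnn53)C(=O)NC4=O)c2c1` gives 64000 nM

All three values come from a functional assay on Hs 683 cells (Homo sapiens) for cytotoxicity, read by MTT assay, with a stated time of 72 h (on this read-out lower numbers stand for stronger inhibition and higher numbers for weaker inhibition), and compound 2 stands second highest of the three, with compound 3 higher and compound 1 lower. Compound 4 (`Cc1ccc2[nH]c(-c3ccc[nH]3)c(C3CC(=O)NC3=O)c2c1`) is not yet measured and differs from compound 2 by methyl in place of hydrogen on an aromatic carbon. Among the compounds with values here, the one measured step bearing on this is a 4.2-fold higher number from compound 1 to compound 2 (0.62 log units; beyond the scatter) and it is modest. That step concerns methoxy on the same aromatic carbon, and read in reverse it goes towards the lower number. Compound 3 also carries a methyl, but on a different core, so no single change links it to compound 2. A modest move towards the lower number is therefore expected, no larger than the methoxy step. The expected step in this assay is a 2.3-fold lower number from compound 2 to compound 4 (0.36 log units; beyond the scatter) and it rests on a single pair. The value of compound 4 is estimated at 11000 nM (range 4000 nM to 30000 nM).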

Compound 4, half-maximal inhibitory concentration: 8000 nM
Compound 4: middle estimate off by 1.4-fold (0.14 log units), on the high side; the measured number falls inside the stated range.
By their numbers in this assay, from the lowest: compounds 1 and 4 (each within the scatter of the next); then compound 2; then compound 3.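

In this assay, the step of a 3.1-fold lower number from compound 2 to compound 4 (0.49 log units; beyond the scatter) shows that a group on this aromatic carbon moves the number down without any oxygen attached, since methyl here enters as a single carbon with no hydrogen-bond acceptors. Exchanging methoxy for methyl gives a 1.3-fold higher number from compound 1 to compound 4 (0.12 log units; within the scatter), which lies within the scatter, so the two groups are not separated at this position on this read-out. No measurement on hand accounts for either step.

The compounds shown leave open whether the lower number follows from substitution at this carbon in general or holds only for methyl and methoxy, which a chlorine atom, an amine or a carboxylic acid there would test. A longer chain such as ethyl would show whether the trend continues past a single carbon.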